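Ghrelin receptor sulfonamide series: methoxy to chloro on the distal ring

A few compounds are considered here, and "the series" means these few. Any claim that something is new, unique, unknown or untested is made for them only; others in the source may bear on it.

Measured so far:
compound 1, `COc1ccc(NS(=O)(=O)c2ccc(-c3ccccn3)s2)cc1N1C[C@@H](C)N[C@@H](C)C1`: 15.9 nM
compound 2, `COc1ccc(F)c(-c2ccc(S(=O)(=O)Nc3cc(N4C[C@@H](C)N[C@@H](C)C4)ccc3OC)cc2)c1`: 0.398 nM

In a functional assay for agonist activity at growth hormone secretagogue receptor type 1 (Homo sapiens), read by FLIPR (a lower number here means that less compound is needed, a higher number that more compound is needed for the effect), compound 2 gives 0.398 nM, the lowest of the two numbers; in this assay compound 1 gives 15.9 nM, a higher number, and the gap lies beyond the scatter. Among the measured compounds shown here, no step between compounds differing in one place is available, so the two values only show that the change of the whole aryl part between compound 1 and compound 2 is large.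

Compound 3, `COc1ccc(N2C[C@@H](C)N[C@@H](C)C2)cc1NS(=O)(=O)c1ccc(-c2cc(Cl)ccc2F)cc1`, differs from compound 2 by chloro in place of methoxy on an aromatic carbon. The shared core is otherwise unchanged. For the measured compounds named here, with no closely matched pair to lean on, the step from compound 2 to compound 3 is expected to be small, toward a slightly higher number, and possibly not beyond the scatter: a 2.0-fold higher number from compound 2 to compound 3 (0.30 log units; within the scatter) is the estimate. For compound 3 the expected value in this assay is 0.8 nM, with a range from 0.2 nM to 3 nM.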

Compound 3, half-maximal effective concentration: 0.501 nM
For compound 3 the middle estimate is 1.6-fold (0.20 log units) above the measured one; measured number inside the range.
By their numbers in this assay, from the lowest: compounds 2 and 3 (each within the scatter of the next); then compound 1.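

In this assay, among the compounds shown here, chloro in place of methoxy on the aromatic carbon para to a fluoro group gives a 1.3-fold higher number from compound 2 to compound 3 (0.10 log units; within the scatter), the first step that differs in one place. At this position, therefore, the 2-fluoro-5-methoxyphenyl and 5-chloro-2-fluorophenyl groups cannot be told apart in this read-out, even though the leaving methoxy counts one hydrogen-bond acceptor and the entering chloro none, and a number as low as that of compound 2 does not depend on the methoxy group. No measurement on hand accounts for this result.

Still open, from the compounds shown here alone, is how this position responds to groups of another kind, such as an amine, a carboxylic acid or a longer alkoxy chain. Also open, going by these compounds, is what plain hydrogen here would give, or what removing the fluoro group would do.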